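The compounds below may be only part of what the source reports. "The series", "measured", "known", "first", "only" and "open" are said of these compounds alone.

Measured so far:
compound 1 `CC(C)=CCC1Cc2c(OCCCNC(=O)c3ccco3)cc(=O)n(CCCO)c2CC1(C)C` — 2.1%
compound 2 `COc1ccc(NC(=O)Oc2cc(=O)n(CCCO)c3c2CC(CC=C(C)C)C(C)(C)C3)cc1` — 3.7%

In a functional assay on PANC-1 cells (Homo sapiens) for inhibition, read by MTT assay, with a stated time of 24 h, tested at 10 uM (on this read-out lower numbers stand for less inhibition and higher numbers for more inhibition at the one concentration tested (going by the name of the read-out)), compound 2 gives 3.7%, and compound 1 gives 2.1%. Among the measured compounds shown here, the one step between them, a number 1.6 percentage points higher from compound 1 to compound 2 (within the scatter), is within the scatter, so the two numbers stand level and neither compound is set apart; both sit close to the floor of the read-out at the concentration tested.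

Compound 3 `CC(C)=CCC1Cc2c(OC(=O)Nc3ccc(F)cc3)cc(=O)n(CCCO)c2CC1(C)C` differs from compound 2 by fluoro in place of methoxy on an aromatic carbon. For the measured compounds named here, no measured step bears on this change: the only step, a number 1.6 percentage points higher from compound 1 to compound 2 (within the scatter), exchanges the whole group on the aromatic oxygen and says nothing about an exchange on the aryl ring of the carbamate. Given that both measured compounds show almost no inhibition and that their one step is within the scatter, the estimated step is a number 0.2 percentage points lower from compound 2 to compound 3 (within the scatter). Compound 3 is therefore estimated at 3.5%, with a range from -6% to 13%, resting only on the two values at hand.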

Compound 3, a percentage reported as inhibition, at one concentration (the size of the read-out at that concentration, not a potency): 71.2%
Beside the measured number, compound 3's estimate is 67.7 percentage points below it; the measured number lies above the stated range.
By their numbers in this assay, from the lowest: compounds 1 and 2 (each within the scatter of the next); then compound 3.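

In this assay, the substituent on the aryl ring of the carbamate emerges as the feature that decides the read-out: fluoro in place of methoxy on this aromatic carbon, para to a large group, gives a number 67.5 percentage points higher from compound 2 to compound 3 (beyond the scatter), with the rest of the molecule unchanged. The earlier step could not show this, since (4-methoxyphenyl)carbamoyl in place of the 3-(((furan-2-yl)carbonyl)amino)propyl group gave a number 1.6 percentage points higher from compound 1 to compound 2 (within the scatter), whereas (4-fluorophenyl)carbamoyl in the same place gives a number 69.1 percentage points higher from compound 1 to compound 3 (beyond the scatter). Across these three compounds, then, the carbamoyl group alone does not set the number, and the group on its aryl ring does. No supporting data at hand explain this change.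

Whether the gain comes from the presence of fluoro or from the loss of methoxy stays open, as only these two groups are shown at this aromatic carbon, and chloro, methyl or plain hydrogen there would help to separate the two readings. Also open, from the compounds shown here alone, is whether the fluoro effect holds when the carbamate link itself is exchanged, for instance for a urea or an amide.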